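Methoxy for fluoro on the aryl ring of compound 3

The source may report more compounds than this note shows. Statements on the series, on what has been measured and on what is new or still open speak of the compounds shown alone.

Three members of the series have numbers in a functional assay on QGY7701 cells (Homo sapiens) for cytotoxicity, read by MTT assay, with a stated time of 24 h; on this read-out lower numbers stand for stronger inhibition and higher numbers for weaker inhibition. Compound 1 `C=CC1=C(C(=O)NC2CCCCC2)C(c2ccc(OC)c(OC)c2)OC1` gives 7490 nM. Compound 3 `C=CC1=C(C(=O)NCc2ccc(OC)c(OC)c2)C(c2ccc(F)cc2)OC1` gives 87300 nM. For compound 2 `C=CC1=C(C(=O)NCc2ccc(Cl)cc2)C(c2ccc(OC)cc2)OC1` the assay reports only a limit, > 100000 nM, and that limit is the one described as the limit of > 100000 nM in this assay, at which 1 of the 3 values shown sits. Among the two actual numbers, compound 3 sits at the higher one; compound 1 lies at a lower number, a gap that is beyond the scatter.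

Compound 4 `C=CC1=C(C(=O)NCc2ccc(OC)c(OC)c2)C(c2ccc(OC)cc2)OC1` is not yet measured. It differs from compound 3 by methoxy in place of fluoro on an aromatic carbon; in words, methoxy in place of fluoro on an aromatic carbon. Among the measured compounds shown here, no measured pair shows this change on its own, so no measured step can be quoted for it. The expectation is a step of no size beyond the scatter, with a slight lean toward a higher number. The step from compound 3 to compound 4 is expected as a 1.1-fold higher number from compound 3 to compound 4 (0.06 log units; within the scatter). For compound 4 the estimate in this assay is 100000 nM, expected to fall between 30000 nM and 300000 nM.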

Compound 4, half-maximal inhibitory concentration: > 100000 nM
Compound 4 was reported as a limit; the forecaster's own chance of this, stated with the estimate: 40%; the middle value sits exactly at the limit.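

In this assay, among the compounds shown here, this is the first pair that isolates one change on the aromatic carbon para to a large group: 4-fluorophenyl to 4-methoxyphenyl gives an at least 1.1-fold higher number from compound 3 to compound 4 (0.05 log units; that floor lies within the scatter). Compound 4 gives only a limit, > 100000 nM, so the step has a floor but no readable size. Methoxy therefore brings no lower number at this place, and a second compound now stands at the top of the range: the limit of > 100000 nM in this assay, at which 2 of the 4 values shown sit.

On these data alone, it remains open how this change would read on an amide partner that keeps both members of the pair clear of the limit. Also open, as far as these compounds go, is whether an amine or a carboxylic acid on this aromatic carbon would give a lower number than fluoro or methoxy.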